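This account rests on a few compounds, and the source may have more. Where it says the series, first, only, none or still open, it means among the compounds named here.

Measured compounds:
compound 1, `CNC(=O)/C=C1/COc2cc(OS(=O)(=O)c3cccc(Cl)c3)ccc21`: 41 nM
compound 2, `CNC(=O)/C=C1/COc2c1ccc(OS(=O)(=O)c1ccccc1)c2C`: 9.8 nM

In an assay (strain Sprague-Dawley) for inhibition of Amine oxidase [flavin-containing] A (Rattus norvegicus), read by spectrophotometry, with a stated time of 5 min (on this read-out lower numbers stand for stronger inhibition and higher numbers for weaker inhibition), compound 2 gives 9.8 nM, the lowest of the two numbers. Compound 1 gives 41 nM, a gap beyond the scatter. Compound 3, `CNC(=O)/C=C1/COc2c1ccc(OS(=O)(=O)c1cccc(Cl)c1)c2C`, differs from compound 2 by chloro in place of hydrogen on an aromatic carbon. Among the compounds with values here, no measured pair shows this change alone; compound 1 carries the same chloro but on a differently arranged core without the methyl, so its value is no direct guide. The expected step, a 1.0-fold higher number from compound 2 to compound 3 (0.01 log units; within the scatter), is small, in either direction, and likely not beyond the scatter. Compound 3 is estimated at 10 nM, within a range from 3 nM to 35 nM.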

Compound 3, half-maximal inhibitory concentration: 24 nM
The estimate for compound 3 lay 2.4-fold (0.38 log units) below the measured number; low and high end bracket the measured number.
By their numbers in this assay, from the lowest: compound 2; then compounds 3 and 1 (each within the scatter of the next).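

In this assay, within the data shown here, the change from phenyl to 3-chlorophenyl gives a 2.4-fold higher number from compound 2 to compound 3 (0.39 log units; beyond the scatter), the first direct reading of chloro at this place, and it is a modest weakening rather than the neutral step a hydrogen swap might suggest. With chloro present, the added methyl gives a 1.7-fold lower number from compound 1 to compound 3 (0.23 log units; within the scatter), so this pair does not separate the two compounds. Nothing shown accounts for either step. Still open, from the compounds shown here alone, is whether an amine or a carboxylic acid at the same place would read like chloro, and what methyl does when the phenyl carries no chloro.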